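A few compounds are considered here, and "the series" means these few. Any claim that something is new, unique, unknown or untested is made for them only; others in the source may bear on it.

In a functional assay on A549 cells (Homo sapiens) for antiproliferative activity, read by MTT assay, with a stated time of 48 h (on this read-out lower numbers stand for stronger inhibition and higher numbers for weaker inhibition), compound 1 (`CCOc1cc(-c2ccc3cc[nH]c3c2)cn2c(-c3cc(OC)c(OC)c(OC)c3)nnc12`) gives 626 nM and compound 2 (`COc1cc(-c2nnc3c(OC)cc(-c4ccc5[nH]ccc5c4)cn23)cc(OC)c1OC`) gives 167 nM so compound 1 holds the higher of these two numbers. Compound 3 (`COc1cc(-c2nnc3c(OC)cc(-c4ccc5[nH]cc(C=O)c5c4)cn23)cc(OC)c1OC`) gives > 10000 nM as a limit and not a number. Compound 4 (`CCOc1cc(-c2ccc3c(ccn3C)c2)cn2c(-c3cc(OC)c(OC)c(OC)c3)nnc12`) departs from compound 1 in one place, the change being 1-methyl-1H-indol-5-yl in place of 1H-indol-6-yl on an aromatic carbon on the shared core. Among the compounds with values here, the only measured step in one place is an at least 59-fold higher number from compound 2 to compound 3 (1.77 log units; beyond the scatter) and it is large, yet it concerns a formyl group, so it bears on the present change only loosely. Within the data shown here, no measured step isolates the change to 1-methyl-1H-indol-5-yl. With compound 2 at 167 nM as the nearest number, a moderate step to a lower number is expected in this assay rather than a loss of activity on the scale of the formyl step, and it may not clear the scatter. The expected change is a 1.4-fold lower number from compound 1 to compound 4 (0.14 log units; within the scatter) and remains an estimate. For compound 4 the estimated value is 450 nM with an expected range from 120 nM to 2500 nM in this assay.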

Compound 4, half-maximal inhibitory concentration: 334 nM
The estimate for compound 4 lay 1.3-fold (0.13 log units) above the measured number; low and high end bracket the measured number.
By their numbers in this assay, from the lowest: compounds 2, 4 and 1 (each within the scatter of the next, the first and the last beyond it). At a limit, above all of these: compound 3.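

In this assay, the replacement at this position of the shared core gives a 1.9-fold lower number from compound 1 to compound 4 (0.27 log units; within the scatter), so 1-methyl-1H-indol-5-yl is accepted on this aromatic carbon, two atoms from the ring nitrogen, in the presence of the ethoxy group. The entering group has no hydrogen-bond donor and the leaving group has one, so activity in this assay is not shown to require that donor on this group. No available evidence bears on the cause of this step.

Within the data shown here, the single step changes both the attachment point and the methyl on the indole nitrogen, so the contribution of each remains unresolved. From the compounds shown here alone, it also remains open whether a longer chain or an amine-bearing chain on that nitrogen would be accepted in place of the methyl.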